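Putting an imidazole back in place of cyclohexyl

The source may hold more compounds than are shown below. What is called first, only, known or untested is meant among the compounds shown, and "the series" means these compounds.

In a functional assay on NCI-H460 cells (Homo sapiens) for cytotoxicity, read by MTT assay, with a stated time of 72 h (a lower number here means a stronger inhibitor, a higher number a weaker inhibitor), compound 1 `O=c1[nH]/c(=C\c2nc[nH]c2C2CC2)c(=O)[nH]/c1=C\c1cccc(Oc2ccc(F)cc2)c1` gives 15.2 nM. Compound 2 `O=c1[nH]/c(=C\C2CCCCC2)c(=O)[nH]/c1=C\c1cccc(Oc2ccc(F)cc2)c1` gives > 1000 nM in this assay, and this is a limit of the assay, not a number. Compound 3 `O=c1[nH]/c(=C\c2ncc[nH]2)c(=O)[nH]/c1=C\c1cccc(Oc2ccc(F)cc2)c1` keeps the shared core and changes one group: 1H-imidazol-2-yl in place of cyclohexyl on a double-bonded chain carbon bound to an aromatic carbon. Going by the values given here, the only measured step that bears on this swap is an at least 65-fold higher number from compound 1 to compound 2 (1.81 log units; beyond the scatter), which was large and beyond the scatter, and it ran from an imidazole group to cyclohexyl. Compound 3 reverses that kind of change, but 1H-imidazol-2-yl is not the same group as the 5-cyclopropyl-1H-imidazol-4-yl of compound 1, which gives 15.2 nM. Only part of the gap is therefore expected to close. The expected change is a clear move to a lower number, an at least 8.3-fold lower number from compound 2 to compound 3 (0.92 log units; beyond the scatter). Compound 3 is estimated at 120 nM, with an expected range of 25 nM to 700 nM.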

Compound 3, half-maximal inhibitory concentration: > 1000 nM
Compound 3: only a limit was reported; the forecaster's own chance of this, stated with the estimate: 15%; middle value at least 8.3-fold (0.92 log units) away from the limit.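

An imidazole ring on this double-bonded chain carbon is not enough by itself: 1H-imidazol-2-yl in place of 5-cyclopropyl-1H-imidazol-4-yl gives an at least 65-fold higher number from compound 1 to compound 3 (1.81 log units; beyond the scatter) in this assay. The strong value of compound 1 therefore depends on something particular to its 5-cyclopropyl-1H-imidazol-4-yl group, not on the presence of any imidazole. The step from compound 2 to compound 3 cannot be read, and the two compounds cannot be ranked, since both values are limits and not numbers: the limit of > 1000 nM in this assay, at which 2 of the 3 values shown sit.

The two imidazole groups differ both in the cyclopropyl and in how the ring is attached, and the compounds shown do not separate these two changes. A plain 1H-imidazol-4-yl group, or a 5-methyl-1H-imidazol-4-yl group, would help show which of them matters.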